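The compounds below may be only part of what the source reports. "The series", "measured", "known", "first", "only" and "open" are said of these compounds alone.

Measured compounds:
Compound 1 `CC1(c2ccccc2)CC(=O)N(CC(=O)N2CCN(c3ccc(F)cc3)CC2)C1=O` gives "not active" (no number reported) in a functional assay on the whole organism (strain CD-1) with Mus musculus as the target, with a stated time of 0.5 h; a lower number here means that less compound is needed, a higher number that more compound is needed for the effect.
Compound 2 `CC1(c2ccccc2)CC(=O)N(CC(=O)N2CCN(c3ccc(Cl)cc3)CC2)C1=O` gives 300 mg/kg in this assay.
Compound 3 `Cc1cccc(N2CCN(C(=O)CN3C(=O)CC(C)(c4ccccc4)C3=O)CC2)c1` gives "not active" (no number reported) in this assay.

Compound 1 stands without a single number in this assay: the read-out for it is an outcome rather than a dose, and compound 3 shares that situation. Only compound 2 returns a figure, and that figure is a high one. With two of three measured compounds lacking a number, compound 1 cannot be placed on a scale relative to the others; all that can be said is that the three differ only in the aryl group on the ring nitrogen and that one of them, compound 2, reached a reported minimum effective dose.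

The unmeasured compound 4 `COc1ccccc1N1CCN(C(=O)CN2C(=O)CC(C)(c3ccccc3)C2=O)CC1` follows from compound 1 by a single change, (2-methoxyphenyl in place of 4-fluorophenyl on an amine nitrogen in a ring). The change brings a 2-methoxyphenyl where a 4-fluorophenyl stood, on an amine nitrogen in a ring, and adds one hydrogen-bond acceptor while keeping the count of rings and the charge unchanged.

Within the data shown here, no step between measured compounds is available to size this move in this assay. Given that compound 1 and compound 3 gave no number, and that compound 2 alone reached a high dose, the expectation for compound 4 is either no reported number or a dose of similar magnitude, with no direction beyond the scatter that can be supported. Compound 4 is therefore estimated at 300 mg/kg in this assay, with an expected range from 100 mg/kg to 1000 mg/kg.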

Compound 4, minimum effective dose: "not active" (no number reported)
For compound 4 the study gives words and no number, so the estimate cannot be set against anything.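

In this assay compound 4 gives "not active" (no number reported) and compound 1 gives "not active" (no number reported), and no step can be read between these two compounds. The compounds shown leave open how the minimum effective dose shifts with the group on the ring amine nitrogen, with compound 2 alone returning a number. No evidence bears on this result.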